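Cytotoxicity of Nucleoside Analogues with Varied Amine Substituents

A few compounds are considered here, and "the series" means these few. Any claim that something is new, unique, unknown or untested is made for them only; others in the source may bear on it.

Compound 1: `Cc1cn([C@@H]2O[C@H](CO[Si](C)(C)C(C)(C)C)[C@@]3(OS(=O)(=O)C=C3NCC(=O)C(=O)N3CCC3)[C@H]2O[Si](C)(C)C(C)(C)C)c(=O)n(C)c1=O` — 65000 nM
Compound 2: `Cc1cn([C@@H]2O[C@H](CO[Si](C)(C)C(C)(C)C)[C@@]3(OS(=O)(=O)C=C3NCC(=O)OCc3ccccc3)[C@H]2O[Si](C)(C)C(C)(C)C)c(=O)n(C)c1=O` — >= 400000 nM

In a functional assay on HEL cells (Homo sapiens) for cytotoxicity, read by microscopy (on this read-out lower numbers stand for higher toxicity in this test and higher numbers for lower toxicity in this test), compound 1 gives 65000 nM. For compound 2 the result is a limit of the test, >= 400000 nM, which is the limit of >= 400000 nM in this assay, at which 1 of the 2 values shown sits. Going by the values given here, the one measured step, an at least 6.1-fold higher number from compound 1 to compound 2 (0.78 log units; beyond the scatter), therefore reaches only this limit; compound 2 stands at the least toxic edge of what the test can report.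

Compound 3, `CCNC(=O)NC1=CS(=O)(=O)O[C@@]12[C@@H](CO[Si](C)(C)C(C)(C)C)O[C@@H](n1cc(C)c(=O)n(C)c1=O)[C@@H]2O[Si](C)(C)C(C)(C)C`, differs from compound 2 by the change (ethylcarbamoyl in place of (benzyloxycarbonyl)methyl on an amine nitrogen). Among the compounds with values here, no measured step covers ethylcarbamoyl in place of (benzyloxycarbonyl)methyl on this amine nitrogen, so the step from compound 1 to compound 2 bears on it only loosely, as a sign that this region of the core is sensitive. Compound 3 is expected at 200000 nM, between 50000 nM and 400000 nM, which would mean an estimated step of an at least 2.0-fold lower number from compound 2 to compound 3 (0.30 log units; that floor lies within the scatter) in this assay, with a real chance that only a limit is returned again.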

Compound 3, minimum cytotoxic concentration: >= 3200 nM
Compound 3: no number, only a limit; the forecaster's own chance of this, stated with the estimate: 50%; the middle value does not contradict the limit.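

In this assay compound 3 returns only a limit, >= 3200 nM. Going by these compounds alone, no step from compound 2 or compound 1 to compound 3 can be read. From the compounds shown here alone, how ethylcarbamoyl on this amine nitrogen compares with the substituents of compound 1 and compound 2 therefore stays open.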